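A few compounds are considered here, and "the series" means these few. Any claim that something is new, unique, unknown or untested is made for them only; others in the source may bear on it.

Measured in a functional assay on the whole organism for inhibition, with Rattus norvegicus as the target; on this read-out higher numbers stand for an effect only at larger amounts of compound and lower numbers for an effect already at smaller amounts:
- compound 1 `CCCc1nc(CO)c(C(=O)OCC)n1Cc1ccc(-c2ccccc2C(=O)O)cc1`: 1.5 mg/kg
- compound 2 `CCCc1nc(CO)c(C(=O)O)n1Cc1ccc(-c2ccccc2C(=O)O)cc1`: 0.069 mg/kg
- compound 3 `CCCc1nc(C(=O)O)c(CO)n1Cc1ccc(-c2ccccc2C(=O)O)cc1`: 8.8 mg/kg

Compound 3 has the highest number of the three, clearly above both compound 1 and compound 2 in this assay. The next structure is compound 4 `CCCc1nc(CO)c(CO)n1Cc1ccc(-c2ccccc2C(=O)O)cc1`, which differs from compound 3 as follows: hydroxymethyl in place of carboxy on an aromatic carbon. In words, hydroxymethyl takes the place of carboxy on an aromatic carbon, so that carbon and its neighbour both bear hydroxymethyl.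

For the measured compounds named here, the one measured step, a 22-fold lower number from compound 1 to compound 2 (1.34 log units; beyond the scatter), is large, but it bears only indirectly. It puts hydrogen in place of ethyl on an oxygen next to a carbonyl group, and no carboxy is exchanged for hydroxymethyl. Compound 2 and compound 3 carry the same two groups exchanged on the shared core, and their values differ widely, with compound 2 at 0.069 mg/kg and compound 3 at 8.8 mg/kg. Going by the values given here, the carboxy therefore does not give one outcome wherever it sits, and no measured pair shows its removal from this carbon.

Among the compounds with values here, with so little direct evidence, no step clearly beyond the scatter is expected, and the expected change is a 1.8-fold lower number from compound 3 to compound 4 (0.25 log units; within the scatter). For compound 4 the estimated value is 5 mg/kg, with an expected range from 1 mg/kg to 25 mg/kg.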

Compound 4, dose for 50% inhibition: 2.1 mg/kg
Beside the measured number, compound 4's estimate is 2.4-fold (0.38 log units) above it, and the stated range covers the measured number.
By their numbers in this assay, from the lowest: compound 2; then compounds 1 and 4 (each within the scatter of the next); then compound 3.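

In this assay the same exchange, hydroxymethyl in place of carboxy on an aromatic carbon, gives changes in opposite directions on the two carbons: the step at the carbon two ring bonds from the ring atom that bears a large group is a 4.2-fold lower number from compound 3 to compound 4 (0.62 log units; beyond the scatter) and the step at the carbon that holds ethoxycarbonyl in compound 1 is a 30-fold higher number from compound 2 to compound 4 (1.48 log units; beyond the scatter) on the same read-out. Carboxy therefore goes with the higher number at the first carbon and with the lower number at the second, so its outcome depends on where it sits among these compounds. For the compounds shown here, at the second carbon, hydroxymethyl and ethoxycarbonyl stay apart by only a 1.4-fold higher number from compound 1 to compound 4 (0.15 log units; within the scatter) and cannot be ordered, which leaves carboxy in compound 2 as the one group of the three set clearly apart there.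

On these data alone, whether an aminomethyl group or a primary amide on either carbon would follow carboxy or hydroxymethyl stays open, as does the effect of a longer chain in place of propyl. The compounds shown carry no measurement that accounts for the opposite directions of this exchange.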